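This account rests on a few compounds, and the source may have more. Where it says the series, first, only, none or still open, it means among the compounds named here.

Compound 1 `O=C(Nc1nc2ccc(Cl)cc2s1)c1cn(-c2ccccc2)nc1-c1ccc(F)cc1` gives 6770 nM in a functional assay on U-87MG ATCC cells for cytotoxicity against U-87 MG (Homo sapiens), read by MTT assay, with a stated time of 72 h; a lower number here means a stronger inhibitor, a higher number a weaker inhibitor. Compound 2 `COc1ccc2nc(NC(=O)c3cn(-c4ccccc4)nc3-c3ccc(F)cc3)sc2c1` differs from it by methoxy in place of chloro on an aromatic carbon. In this assay compound 2 gives > 50000 nM, which is a limit of the assay rather than a number, as the limit of > 50000 nM in this assay, at which 1 of the 3 values shown sits, records. The step is an at least 7.3-fold higher number from compound 1 to compound 2 (0.86 log units; beyond the scatter). Compound 3 `O=C(Nc1nc2ccccc2s1)c1cn(-c2ccccc2)nc1-c1ccc(Cl)cc1` carries a different core, and the difference between the two cores is not broken down here; in this assay compound 3 gives 11500 nM, a value close to that of compound 1. Compound 4 `COc1ccc(-c2nn(-c3ccccc3)cc2C(=O)Nc2nc3ccccc3s2)cc1` is derived from compound 3 by methoxy in place of chloro on an aromatic carbon. This is the same kind of change as that from compound 1 to compound 2, but not the same: in compound 2 the group sits on a ring that is part of a fused or bridged system of two rings, meta to a fused ring and para to a fused ring, whereas in compound 4 it sits para to a large group on a six-membered aromatic ring of carbon only. Compound 4 is expected to show a 3.0-fold higher number from compound 3 to compound 4 (0.48 log units; beyond the scatter), resting on the weakening recorded in an at least 7.3-fold higher number from compound 1 to compound 2 (0.86 log units; beyond the scatter). Compound 4 is therefore estimated at 35000 nM, plausibly between 10000 nM and 80000 nM.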

Compound 4, half-maximal inhibitory concentration: 11500 nM
Compound 4: middle estimate off by 3.0-fold (0.48 log units), on the high side; low and high end bracket the measured number.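

In this assay, methoxy in place of chloro gives no change at the digits printed from compound 3 to compound 4 (within the scatter), so the weakening seen on the core of compound 1 did not carry over to the core of compound 3: the same change on two cores in this assay, an at least 7.3-fold higher number (0.86 log units; beyond the scatter) from compound 1 to compound 2 and no change at the digits printed (within the scatter) from compound 3 to compound 4, at least 7.3-fold (0.86 log units) apart, beyond the scatter of two such steps. This shows that the change cannot be carried between these cores as one fixed step, but the two changes also sit at different places, and the pair does not separate the effect of place from that of core. The step from compound 1 also ends at a limit, not a number: the limit of > 50000 nM in this assay, at which 1 of the 4 values shown sits.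

The compounds shown leave open how an amine or a carboxylic acid would read in place of the chloro on either core. They also leave open whether methoxy at the same place on both cores would give matching steps.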